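Fluoro in Place of Hydroxy: Step from Compound 2

A few compounds are considered here, and "the series" means these few. Any claim that something is new, unique, unknown or untested is made for them only; others in the source may bear on it.

Of the compounds shown here, two on a shared core have been measured in an assay on isolated protein for inhibition of protein deacetylase HDAC6 (Homo sapiens), read by fluorescence, with a stated time of 2 h; a higher number here means a weaker inhibitor, a lower number a stronger inhibitor. Compound 1 `CCCNNC(=O)c1ccc(CNC(=O)c2ccc3cnccc3c2)cc1` gives in this assay only a limit of the assay, > 10000 nM. Compound 2 `CCCNNC(=O)c1ccc(CNC(=O)c2cc3cc(O)ccc3o2)cc1` likewise gives in this assay only a limit of the assay, > 10000 nM. Compound 2 therefore stands at the limit where both shown values sit (the limit of > 10000 nM in this assay, at which 2 of the 2 values shown sit), and no number places it more precisely. Compound 3 `CCCNNC(=O)c1ccc(CNC(=O)c2cc3cc(F)ccc3o2)cc1` differs from compound 2 by fluoro in place of hydroxy on an aromatic carbon. No step between measured compounds exists here, so the size of the step to compound 3 rests on the change alone; a step beyond the scatter in either direction is not supported by what is shown. The estimate for compound 3 implies a step that the limit leaves unreadable from compound 2 to compound 3, none beyond the scatter. Compound 3 is expected to come in at about 20000 nM, within a range from 5000 nM to 80000 nM.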

Compound 3, half-maximal inhibitory concentration: > 10000 nM
Compound 3 ended at the assay's limit; the forecaster's own chance of this, stated with the estimate: 75%; the middle value does not contradict the limit.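

Compound 2 and compound 3 both give only a limit of the assay, so no step from one to the other can be read: the limit of > 10000 nM in this assay, at which 3 of the 3 values shown sit.

The compounds shown leave open how strongly any of them inhibits, and whether fluoro in place of hydroxy shifts that at all.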